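The compounds below may be only part of what the source reports. "The series", "measured", "known", "first", "only" and "open" are said of these compounds alone.

In a functional assay on DU-145 cells (Homo sapiens) for inhibition, read by MTT assay, with a stated time of 48 h (a higher number here means a weaker inhibitor, a lower number a stronger inhibitor), compound 1 (`C(=C/c1nc2ccccn2c1Sc1ccccc1)\c1ccccc1`) reads 22000 nM and compound 2 (`N#Cc1ccc(-c2nc3ccccn3c2Sc2ccccc2)cc1`) reads 76500 nM while compound 3 (`c1ccc(Sc2c(-c3cccs3)nc3ccccn23)cc1`) reads 24100 nM in this series. Compound 3 is not separated from compound 1 (a 1.1-fold higher number from compound 1 to compound 3 (0.04 log units; within the scatter)) but is clearly apart from compound 2 (a 3.2-fold lower number from compound 2 to compound 3 (0.50 log units; beyond the scatter)). Compound 4 (`Clc1ccc(Sc2c(-c3cccs3)nc3ccccn23)cc1`) has chloro in place of hydrogen on an aromatic carbon, phenyl to 4-chlorophenyl. The measured steps, the largest being modest (a 3.5-fold higher number from compound 1 to compound 2 (0.54 log units; beyond the scatter)), all change a different group, so none tests this change directly. No direction is supported by the data, and a step within the scatter is expected (a 1.2-fold lower number from compound 3 to compound 4 (0.08 log units; within the scatter)). Compound 4 is estimated at 20000 nM (9000 nM to 45000 nM).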

Compound 4, half-maximal inhibitory concentration: 92300 nM
Compound 4: middle estimate off by 4.6-fold (0.66 log units), on the low side; the measured number lies above the stated range.
By their numbers in this assay, from the lowest: compounds 1 and 3 (each within the scatter of the next); then compounds 2 and 4 (each within the scatter of the next).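

Among these compounds, until now only the other aromatic group had varied; this step is the first reading of the phenyl on sulfur's replacement site, an aromatic carbon of a six-membered aromatic ring of carbon only, para to a large group. In this assay, chloro in place of hydrogen there is not neutral: it gives a 3.8-fold higher number from compound 3 to compound 4 (0.58 log units; beyond the scatter), so this position responds to a single added chlorine atom. Nothing measured here accounts for the step. On these data alone, whether the rise is specific to chloro remains open, and a methoxy group or an amine at this position would test that. Also open, as far as these compounds go, is whether it holds with 4-cyanophenyl or 2-phenylethenyl in place of thiophen-2-yl.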